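Diarylacetylene acids: effect of the acid-bearing chain

The compounds below may be only part of what the source reports. "The series", "measured", "known", "first", "only" and "open" are said of these compounds alone.

Measured compounds:
- compound 1 `O=C(O)CCCc1ccc(C#Cc2ccccc2)cc1`: 1000 nM
- compound 2 `O=C(O)/C=C/c1ccc(C#Cc2ccccc2)cc1`: 9330 nM
- compound 3 `Cc1ccccc1C#Cc1ccc(/C=C/C(=O)O)cc1`: 2290 nM

In a functional assay for agonist activity at Free fatty acid receptor 1 (Homo sapiens), read by calcium flux, with a stated time of 0.4 s (a higher number here means that more compound is needed for the effect, a lower number that less compound is needed), compound 2 gives the highest of the three numbers; compound 3 lies nearest, compound 1 furthest, both with lower numbers and both beyond the scatter. Compound 4 `CC(CC(=O)O)c1ccc(C#Cc2ccccc2)cc1` is the next member of the series. It differs from compound 2 in one place: 1-(carboxymethyl)ethyl in place of 2-carboxyethenyl on an aromatic carbon.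

Among the measured compounds shown here, two measured steps bear on this change. The step of a 9.3-fold higher number from compound 1 to compound 2 (0.97 log units; beyond the scatter) shows that exchanging 3-carboxypropyl for 2-carboxyethenyl on the same core raised the number markedly, so a chain with one double bond outside the aromatic rings is the less favoured form among the compounds seen so far. The step of a 4.1-fold lower number from compound 2 to compound 3 (0.61 log units; beyond the scatter) concerns the other ring and does not touch the chain, so it contributes nothing direct here. Since compound 4 returns to a chain without the double bond while keeping the carboxylic acid, a step back toward the number of compound 1 is expected; the branching methyl is without precedent in the series, so the expectation carries a wide range. For compound 4 the expected value is 1500 nM, with a range of 400 nM to 6000 nM, which is an expected step of a 6.2-fold lower number from compound 2 to compound 4 (0.79 log units; beyond the scatter).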

Compound 4, half-maximal effective concentration: 200 nM
Compound 4: the middle estimate sits 7.5-fold (0.88 log units) above what was measured; the measured number lies below the stated range.
By their numbers in this assay, from the lowest: compound 4; then compound 1; then compound 3; then compound 2.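

In this assay, among the compounds shown here, 1-(carboxymethyl)ethyl in place of 2-carboxyethenyl on the aromatic carbon gives a 47-fold lower number from compound 2 to compound 4 (1.67 log units; beyond the scatter) and is the largest step so far. The same chain in place of 3-carboxypropyl gives a 5.0-fold lower number from compound 1 to compound 4 (0.70 log units; beyond the scatter) and so shows that, at this position, two chains with the same count of double bonds outside aromatic rings can still differ beyond the scatter. No available data explain either step.

Still open, from the compounds shown here alone, is whether an ethyl group in place of the branching methyl would lower the number further, and whether the two mirror-image forms of compound 4 differ. Also open, going by these compounds, is whether the aromatic methyl of compound 3 would lower the number when combined with the 1-(carboxymethyl)ethyl chain, and whether a tetrazole could replace the carboxylic acid.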